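The source may hold more compounds than are shown below. What is called first, only, known or untested is meant among the compounds shown, and "the series" means these compounds.

The measured compounds are:
compound 1 `Cn1ncc2cc(-c3cnccc3/C=C/C(=O)O)ccc21`, which in an assay on a protein complex for inhibition of CDK8/Cyclin C (Homo sapiens), with a stated time of 1 h (on this read-out lower numbers stand for stronger inhibition and higher numbers for weaker inhibition), gives 34.6 nM;
compound 2 `CNC(=O)CCc1ccncc1-c1ccc2ccccc2c1`, which in this assay gives 21.1 nM;
compound 3 `O=C(O)CCc1ccncc1-c1ccc2ccccc2c1`, which in this assay gives 50.5 nM.

Compound 4 `CNC(=O)/C=C/c1ccncc1-c1ccc2c(cnn2C)c1` has not yet been measured. It differs from compound 1 by methylamino in place of hydroxy on a carbonyl carbon. The same change has already been made between two measured compounds, as methylamino in place of hydroxy on a carbonyl carbon, where it gave a 2.4-fold lower number from compound 3 to compound 2 (0.38 log units; beyond the scatter). The two places are not identical: in compound 3 the carbonyl carbon's other neighbour is a saturated chain carbon, in compound 1 a double-bonded chain carbon, so this is the same kind of change rather than the same one. The difference between the core of compound 1 and that of compound 3 is not broken down here; their two values lie within the scatter of each other. Resting on compound 3 and compound 2, where the step was a 2.4-fold lower number from compound 3 to compound 2 (0.38 log units; beyond the scatter), a step of similar size is expected for compound 4: a 2.0-fold lower number from compound 1 to compound 4 (0.31 log units; beyond the scatter). Compound 4 is therefore estimated at 17 nM, expected to fall between 8 nM and 40 nM.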

Compound 4, half-maximal inhibitory concentration: 86.7 nM
Compound 4: the middle estimate sits 5.1-fold (0.71 log units) below what was measured, outside the stated range (above it).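

In this assay, methylamino in place of hydroxy on a carbonyl carbon gave a 2.5-fold higher number from compound 1 to compound 4 (0.40 log units; beyond the scatter), so the earlier gain did not carry over to this core, and the two steps run in opposite directions: the same change on two cores in this assay, a 2.4-fold lower number (0.38 log units; beyond the scatter) from compound 3 to compound 2 and a 2.5-fold higher number (0.40 log units; beyond the scatter) from compound 1 to compound 4, 6.0-fold (0.78 log units) apart, beyond the scatter of two such steps

The two pairs differ both in the core and in the carbonyl carbon's other neighbour, a saturated chain carbon in compound 3 and a double-bonded chain carbon in compound 1. The data do not separate these two differences, and two pairs give no general rule for the series.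

Still open, as far as these compounds go, is how the same change would read with the double-bonded chain on the core of compound 3, or the saturated chain on the core of compound 1. Also open, from the compounds shown here alone, is whether other groups on the carbonyl carbon, such as amino or dimethylamino, would follow methylamino on either core.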